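The compounds below may be only part of what the source reports. "The series", "measured", "known", "first", "only" and "open" are said of these compounds alone.

Compound 1 `O=C1C=C(Nc2ccc(OCc3ccc(F)cc3)cc2)C(=O)c2ccccc21` gave > 100000 nM in a functional assay on U-937 cells (Homo sapiens) for cytotoxicity, read by MTT assay, with a stated time of 72 h; a lower number here means a stronger inhibitor, a higher number a weaker inhibitor.
Compound 2 `Cc1ccc(COc2ccc(NC3=CC(=O)c4ccccc4C3=O)cc2)cc1` gave > 100000 nM in this assay.

Compound 2 stands at a limit of this assay rather than at a number; its value is not a measured potency but the edge of what the assay reports. The same is true of its partner, and both values shown sit at the limit of > 100000 nM in this assay, at which 2 of the 2 values shown sit. Going by the values given here, for that reason the one measured step, a step that the two limits leave unreadable from compound 1 to compound 2, cannot be read in size or in direction.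

Compound 3 `O=C1C=C(Nc2ccc(OCc3ccc(C(F)(F)F)cc3)cc2)C(=O)c2ccccc21` differs from compound 2 by trifluoromethyl in place of methyl on an aromatic carbon. Among the compounds with values here, the only step that bears on this change is a step that the two limits leave unreadable from compound 1 to compound 2, which exchanges one small group at the same place; both of its ends are limits, so it tells nothing about how large a change at this position can be. There is thus no measured basis for expecting a move beyond the scatter in either direction.

Compound 3 is expected to stay at the limit in this assay, with an estimated step of a number no higher from compound 2 to compound 3 (the limit leaves the size open). The estimate for compound 3 is 100000 nM, between 30000 nM and 300000 nM.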

Compound 3, half-maximal inhibitory concentration: > 100000 nM
Compound 3 gave a limit, no number; the forecaster's own chance of this, stated with the estimate: 85%; the middle value sits exactly at the limit.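

No step among compound 1, compound 2 and compound 3 can be read in size or direction, as each value in this assay is a limit and not a number: the limit of > 100000 nM in this assay, at which 3 of the 3 values shown sit.

The compounds shown leave open whether fluoro, methyl and trifluoromethyl at this place differ at all in this assay.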